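The source may hold more compounds than are shown below. What is called first, only, known or untested is meant among the compounds shown, and "the series" means these compounds.

Measured compounds in a functional assay on U-937 cells (Homo sapiens) for inhibition, read by ELISA, with stated times of 1 h and 24 h; on this read-out higher numbers stand for weaker inhibition and lower numbers for stronger inhibition:
compound 1, `OCc1cn(Cc2cn(-c3ccccc3)nc2-c2ccc(Cl)cc2)nn1`: 6230 nM
compound 2, `OCc1cn(Cc2cn(-c3ccccc3)nc2-c2ccccc2)nn1`: 8120 nM
compound 3, `COc1ccc(-c2nn(-c3ccccc3)cc2CO)cc1`: 8240 nM

Compound 3 stands at the top of the three numbers, yet its gaps to compound 2 and to compound 1 both lie within the scatter, so the three are indistinguishable. Among the compounds with values here, the single measured step, a 1.3-fold higher number from compound 1 to compound 2 (0.12 log units; within the scatter), concerns a substituent on the outer aryl ring of two triazole-bearing compounds and does not touch the change at hand. Compound 4, `COc1ccc(-c2nn(-c3ccccc3)cc2Cn2cc(CO)nn2)cc1`, differs from compound 3 by 4-(hydroxymethyl)-1H-1,2,3-triazol-1-yl in place of hydroxy on a saturated chain carbon bound to an aromatic carbon. Within the data shown here, no measured pair isolates this change; compounds 1 and 2 carry the same triazole arm and sit close to compound 3, which hints that the arm does not move the number far. Compound 4 is therefore expected to give 7000 nM (range 3000 nM to 16000 nM), a step of a 1.2-fold lower number from compound 3 to compound 4 (0.07 log units; within the scatter) that is expected to stay within the scatter.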

Compound 4, half-maximal inhibitory concentration: 9500 nM
Estimate against measurement, compound 4: 1.4-fold (0.13 log units) below, and the stated range covers the measured number.
By their numbers in this assay, from the lowest: compounds 1, 2, 3 and 4 (each within the scatter of the next).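

In this assay, 4-(hydroxymethyl)-1H-1,2,3-triazol-1-yl in place of hydroxy on the saturated chain carbon gives a 1.2-fold higher number from compound 3 to compound 4 (0.06 log units; within the scatter) so this position takes the much larger group with no readable change. With that group present, methoxy in place of hydrogen on an aromatic carbon gives a 1.2-fold higher number from compound 2 to compound 4 (0.07 log units; within the scatter) and methoxy in place of chloro gives a 1.5-fold higher number from compound 1 to compound 4 (0.18 log units; within the scatter) so neither swap separates the compounds. No evidence at hand accounts for this flat picture.

Still open, going by these compounds, is whether an amine or a carboxylic acid in place of the hydroxy on the hydroxymethyl arm would give a number beyond the scatter. The same holds for a longer chain carrying the triazole.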